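Replacing a bromophenyl with a pyridinyl on the thiourea

The compounds below may be only part of what the source reports. "The series", "measured", "known", "first", "only" and "open" are said of these compounds alone.

Of the compounds shown here, two sharing one core have been tested in a functional assay on MKN-74 cells (Homo sapiens) for antiproliferative activity, with a stated time of 24 h; a higher number here means a weaker inhibitor, a lower number a stronger inhibitor. Compound 1 `NC(=O)c1c(NC(=O)c2ccccc2Cl)sc2c1CCN(Cc1ccc(Cl)cc1Cl)C2` gives 16300 nM. Compound 2 `NC(=O)c1c(NC(=O)c2ccccc2Cl)sc2c1CCN(C(=S)Nc1ccccc1Br)C2` gives 10800 nM. For the measured compounds named here, the single measured step, a 1.5-fold lower number from compound 1 to compound 2 (0.18 log units; within the scatter), leaves the two compounds indistinguishable on these numbers, so compound 2 stands nowhere apart from compound 1. Compound 3 `NC(=O)c1c(NC(=O)c2ccccc2Cl)sc2c1CCN(C(=S)Nc1cccnc1)C2` has not yet been measured; its change from compound 2 is pyridin-3-yl in place of 2-bromophenyl on an amide-type nitrogen. Going by the values given here, no measured step touches this part of the molecule: the one known step alters the whole group on the amine nitrogen in a ring rather than the ring attached to the amide-type nitrogen, and that step itself stayed within the scatter. Nothing here points in either direction, so the expected step is a 1.1-fold higher number from compound 2 to compound 3 (0.05 log units; within the scatter), not beyond the scatter. The estimate for compound 3 in this assay is 12000 nM, within a range from 4500 nM to 32000 nM.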

Compound 3, half-maximal inhibitory concentration: 38600 nM
Estimate against measurement, compound 3: 3.2-fold (0.51 log units) below; the whole stated range lies below it.
By their numbers in this assay, from the lowest: compounds 2 and 1 (each within the scatter of the next); then compound 3.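

In this assay, for the compounds shown here, the ring on the amide-type nitrogen clearly counts: pyridin-3-yl in place of 2-bromophenyl gives a 3.6-fold higher number from compound 2 to compound 3 (0.55 log units; beyond the scatter) and is the first single change here to go beyond the scatter. Going by these compounds alone, changing the whole group on the amine nitrogen in a ring now also registers, with a 2.4-fold higher number from compound 1 to compound 3 (0.37 log units; beyond the scatter), whereas the one earlier step of that kind stayed within the scatter. Nothing at hand explains why the number rises with this change.

The compounds shown leave open whether the loss of the bromine or the arrival of the ring nitrogen accounts for the step. A plain phenyl on the same nitrogen would separate the two, and pyridin-2-yl or pyridin-4-yl would show whether the place of the ring nitrogen matters.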